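Swapping the Benzyl Substituent in a Weak Hydrolase Inhibitor

This account rests on a few compounds, and the source may have more. Where it says the series, first, only, none or still open, it means among the compounds named here.

Going by the values given here, compound 2 `O=c1c2cnn(-c3ccc(F)cc3)c2ncn1CC1(O)CCN(Cc2ccc(Cl)cc2)CC1` is the only member of this set with a number in an assay on Sf21 cells for inhibition of ubiquitin carboxyl-terminal hydrolase 7 (Homo sapiens), read by spectrophotometry, with stated times of 30 min and 2 h (on this read-out higher numbers stand for weaker inhibition and lower numbers for stronger inhibition), where compound 2 gives 8000 nM; compound 1 `COC(=O)C(c1ccccc1Cl)N1CCC(O)(Cn2cnc3c(cnn3-c3ccc(F)cc3)c2=O)CC1` was run in this assay but compound 1 stands only as "not determined" (no result reported). Compound 3 `N#Cc1ccccc1CN1CCC(O)(Cn2cnc3c(cnn3-c3ccc(F)cc3)c2=O)CC1` differs from compound 2 by 2-cyanophenyl in place of 4-chlorophenyl on a saturated chain carbon bound to an amine nitrogen in a ring. Among the compounds with values here, no measured pair shows what such a swap does here, so any step is a guess; the change from compound 2 to compound 3 is expected to fall within the scatter, no change at the digits printed from compound 2 to compound 3 (within the scatter). Compound 3 is therefore estimated at 8000 nM, with a range of 2500 nM to 25000 nM.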

Compound 3, half-maximal inhibitory concentration: 8100 nM
For compound 3 the middle estimate is 1.0-fold (0.01 log units) below the measured one; the range from low to high includes it.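

In this assay, going by these compounds alone, the first readable step at this position, 4-chlorobenzyl to 2-cyanobenzyl, comes out as a 1.0-fold higher number from compound 2 to compound 3 (0.01 log units; within the scatter) and so stays within the scatter. On a saturated chain carbon bound to an amine nitrogen in a ring, a nitrile-bearing phenyl thus reads the same as a chlorine-bearing one, though this rests on a single pair. Nothing measured here offers an explanation for this result. As far as these compounds go, what an amine or a carboxylic acid on this phenyl would do remains open. So does the effect of a longer chain between the phenyl and the ring nitrogen.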